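Replacing a Benzyl with a Phenoxy Group on the Chain

A few compounds are considered here, and "the series" means these few. Any claim that something is new, unique, unknown or untested is made for them only; others in the source may bear on it.

Measured compounds:
Compound 1, `CCn1nc(C)c2c1CCN(C(C(=O)NC)c1ccccc1)C2CCc1cccc(C(F)(F)F)c1`, in a functional assay on CHO cells for antagonist activity at Orexin/Hypocretin receptor type 1 (Homo sapiens), read by FLIPR and calcium flux (a higher number here means a weaker inhibitor, a lower number a stronger inhibitor), gives 358 nM.
Compound 2, `CCn1nc(C)c2c1CCN(C(C(=O)NC)c1ccccc1)C2CCc1cccc(F)c1`, in this assay gives 402 nM.
Compound 3, `CCn1nc(C)c2c1CCN([C@@H](C(=O)NC)c1ccccc1)[C@H]2CCc1ccc(C(F)(F)F)cc1`, in this assay gives 128 nM.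

Compound 3 has the lowest number of the three, and its gaps to compound 1 and to compound 2 both lie beyond the usual scatter, so it is the strongest inhibitor among them.

Compound 4, `CCn1nc(C)c2c1CCN([C@@H](C(=O)NC)c1ccccc1)[C@H]2COc1ccc(C)cc1`, differs from compound 3 by 4-methylphenoxy in place of 4-(trifluoromethyl)benzyl on a saturated chain carbon bound to a saturated ring carbon. Going by the values given here, only one measured step exists, a 1.1-fold higher number from compound 1 to compound 2 (0.05 log units; within the scatter), and it concerns a swap of one fluorine-bearing group for another on an aromatic carbon of a different ring; it stayed within the scatter. Among the compounds with values here, no measured pair tests an oxygen-linked ring in place of a carbon-linked one on the chain, and no pair tests a methyl in place of a trifluoromethyl, so the step to compound 4 has little to lean on.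

Compound 4 is therefore expected to give a number near 250 nM in this assay, with a wide range from 60 nM to 1000 nM. The expected step is a 2.0-fold higher number from compound 3 to compound 4 (0.29 log units; within the scatter), a modest loss that is uncertain in both size and direction.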

Compound 4, half-maximal inhibitory concentration: 10000 nM
Compound 4: the middle estimate sits 40-fold (1.60 log units) below what was measured; the whole stated range lies below it.
By their numbers in this assay, from the lowest: compound 3; then compounds 1 and 2 (each within the scatter of the next); then compound 4.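

In this assay, going by these compounds alone, this saturated chain carbon bound to a saturated ring carbon proves far less forgiving than the earlier compounds suggested: 4-methylphenoxy in place of 4-(trifluoromethyl)benzyl gives a 78-fold higher number from compound 3 to compound 4 (1.89 log units; beyond the scatter). The only earlier step, a 1.1-fold higher number from compound 1 to compound 2 (0.05 log units; within the scatter), stayed within the scatter, so this is the first single change shown to move the number sharply, and it makes the inhibitor much weaker. No measurement here accounts for the size of this loss.

The change alters two things at once, an oxygen entering the link to the aromatic ring and a methyl replacing the trifluoromethyl, and the compounds shown cannot say which one carries the loss. A 4-(trifluoromethyl)phenoxy or a 4-methylbenzyl group on the same carbon would separate the two.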